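Replacing benzyl with a five-membered aromatic ring

The compounds below may be only part of what the source reports. "The series", "measured", "known", "first", "only" and "open" are said of these compounds alone.

Measured so far in a physicochemical assay for lipophilicity, read by HPLC, at pH 7.4 (a higher number here means a more lipophilic compound, a lower number a more polar compound), are three compounds:
compound 1 `COCCOc1cc2oc(=O)n(CCC(=O)O)c2cc1Cl` gives 0.88
compound 2 `O=C(O)CCn1c(=O)oc2cc(OCc3ccccc3)c(Cl)cc21` gives 2.71
compound 3 `C[C@@H](Oc1cc2onc(CCC(=O)O)c2cc1Cl)c1ccc(Cl)cn1` gives 2.91

Compound 2 and compound 3 lie within the scatter of each other, and compound 1 lies well apart from both. The change from compound 2 to compound 4 `C[C@@H](Oc1cc2oc(=O)n(CCC(=O)O)c2cc1Cl)c1ncco1` is a group of 7 heavy atoms (5 carbon, 1 nitrogen, 1 oxygen; one five-membered aromatic ring with 2 hetero atoms) in place of a group of 7 heavy atoms (7 carbon; one six-membered aromatic ring of carbon only), on an oxygen on an aromatic ring in this series. For the measured compounds named here, the one measured step that bears on it, with phenyl in place of methoxymethyl, is a number 1.83 log units higher from compound 1 to compound 2 (beyond the scatter) and it is large. Going by the values given here, compound 3 differs from compound 2 in more than one place and gives no single step. Compound 4 keeps an aromatic ring, a case that the measured step does not test. The expected step is a number 1.01 log units lower from compound 2 to compound 4 (beyond the scatter) and it is a moderate fall beyond the scatter. In this assay the estimate for compound 4 is 1.7 within an expected range of 1.2 to 2.2 as a working figure.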

Compound 4, distribution coefficient: 1.11
Estimate against measurement, compound 4: 0.59 log units above, outside the stated range (below it).
By their numbers in this assay, from the lowest: compounds 1 and 4 (each within the scatter of the next); then compounds 2 and 3 (each within the scatter of the next).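

On the oxygen on an aromatic ring, keeping an aromatic ring does not by itself keep the reading near that of compound 2: in this assay the five-membered aromatic ring with 2 hetero atoms in place of benzyl gives a number 1.60 log units lower from compound 2 to compound 4 (beyond the scatter). The same group in place of the group with no ring gives a number 0.23 log units higher from compound 1 to compound 4 (within the scatter), so a ring at this position does not separate these two compounds. Nothing at hand accounts for the difference between the two rings. Left open is how a thiazole ring or an amine on this oxygen would read, and how much of the step belongs to the defined stereocentre rather than to the ring.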